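The source may hold more compounds than are shown below. What is called first, only, known or untested is meant among the compounds shown, and "the series" means these compounds.

Values in a functional assay on MCF7 cells (Homo sapiens) for antiproliferative activity, read by MTT assay, with a stated time of 72 h (a higher number here means a weaker inhibitor, a lower number a stronger inhibitor), for the three compounds measured so far:

- compound 1 `CC1=CC[C@H]2[C@H](CC[C@]2(C)O)C(C)(C)[C@@H]1CC[C@H]1[C@]2(C)CC[C@H](OC(=O)c3ccc(Cl)cc3)C(C)(C)O[C@H]2CC[C@@]1(C)O` gives 24100 nM
- compound 2 `CC1=CC[C@H]2[C@H](CC[C@]2(C)O)C(C)(C)[C@@H]1CC[C@H]1[C@]2(C)CC[C@H](OC(=O)NCc3ccccc3)C(C)(C)O[C@H]2CC[C@@]1(C)O` gives 24500 nM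
- compound 3 `CC1=CC[C@H]2[C@H](CC[C@]2(C)O)C(C)(C)[C@@H]1CC[C@H]1[C@]2(C)CC[C@H](OC(=O)c3cccc([N+](=O)[O-])c3)C(C)(C)O[C@H]2CC[C@@]1(C)O` gives 36000 nM

Compound 3, at 36000 nM in this series, lies within the scatter of both other compounds, and compounds 1 and 2 also lie within the scatter of each other, with a 1.0-fold higher number from compound 1 to compound 2 (0.01 log units; within the scatter) as their step. Compound 4 `CC1=CC[C@H]2[C@H](CC[C@]2(C)O)C(C)(C)[C@@H]1CC[C@H]1[C@]2(C)CC[C@H](OC(=O)c3ccccc3F)C(C)(C)O[C@H]2CC[C@@]1(C)O` keeps the shared core and changes one group, with 2-fluorophenyl in place of 3-nitrophenyl on a carbonyl carbon. Among the compounds with values here, none of the measured compounds carries 2-fluorophenyl, so no measurement speaks to this group directly.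

The closest evidence comes from the two steps that exchange the group on that same carbonyl carbon for 3-nitrophenyl. One is a 1.5-fold higher number from compound 1 to compound 3 (0.17 log units; within the scatter) and the other is a 1.5-fold higher number from compound 2 to compound 3 (0.17 log units; within the scatter), and neither leaves the scatter. These three compounds are a small basis, but on this evidence no step beyond the scatter is expected in this assay, and no direction can be expected with any confidence. The estimated change is a 1.3-fold lower number from compound 3 to compound 4 (0.11 log units; within the scatter) and nothing more. For compound 4 the expected value is 28000 nM, with an estimated range from 14000 nM to 55000 nM.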

Compound 4, half-maximal inhibitory concentration: 11300 nM
Estimate against measurement, compound 4: 2.5-fold (0.39 log units) above, and the stated range ends above it.
By their numbers in this assay, from the lowest: compound 4; then compounds 1, 2 and 3 (each within the scatter of the next).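

In this assay, the group on this carbonyl carbon now shows a measurable effect: the three earlier compounds lay within the scatter of one another, whereas 2-fluorophenyl gives a step beyond the scatter against each of them (a 3.2-fold lower number from compound 3 to compound 4 (0.50 log units; beyond the scatter); a 2.2-fold lower number from compound 2 to compound 4 (0.34 log units; beyond the scatter); a 2.1-fold lower number from compound 1 to compound 4 (0.33 log units; beyond the scatter)). These steps are modest, but they make compound 4 the strongest inhibitor of the four, and the step from 4-chlorophenyl shows that a halogen-bearing phenyl group on this carbonyl carbon does not by itself fix the value. Nothing at hand explains why 2-fluorophenyl gives the lower number.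

The compounds shown cannot separate the contribution of the fluorine from that of its place on the ring, which a comparison with unsubstituted phenyl, 2-chlorophenyl and 4-fluorophenyl would begin to address. They also leave open whether a larger step is possible at this position, for instance with a 2-methoxyphenyl group or a pyridine ring, and whether the lower number for compound 4 would carry over to other cell lines.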